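The compounds below may be only part of what the source reports. "The series", "measured", "known", "first", "only" and "open" are said of these compounds alone.

Measured compounds:
compound 1 `C[C@@H](O[C@H]1CN2C(=O)C=C(c3ccc(CO)cc3)CC2[C@@H]1c1ccc(F)cc1)c1cc(C(F)(F)F)cc(C(F)(F)F)c1`; in an assay on CHO cells for displacement of a labelled ligand from Substance-P receptor (Homo sapiens), in the presence of a further agent that is not named here (on this read-out higher numbers stand for weaker inhibition and lower numbers for stronger inhibition), compound 1 gives 23 nM.
compound 2 `C[C@@H](O[C@H]1CN2C(=O)C=C(c3ccncc3)CC2[C@@H]1c1ccc(F)cc1)c1cc(C(F)(F)F)cc(C(F)(F)F)c1`; in this assay compound 2 gives 8.1 nM.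
compound 3 `C[C@@H](O[C@H]1CN2C(=O)C=C(C3=CCC(O)CC3)CC2[C@@H]1c1ccc(F)cc1)c1cc(C(F)(F)F)cc(C(F)(F)F)c1`; in this assay compound 3 gives 13 nM.

Compound 3 stands second highest of the three numbers; its gaps to compound 2 and to compound 1 both lie within the scatter. Compound 4 `C[C@@H](O[C@H]1CN2C(=O)C=C(C3=CCOCC3)CC2[C@@H]1c1ccc(F)cc1)c1cc(C(F)(F)F)cc(C(F)(F)F)c1` differs from compound 3 in one place: a group of 6 heavy atoms (5 carbon, 1 oxygen; one six-membered non-aromatic ring with 1 hetero atom) in place of a group of 7 heavy atoms (6 carbon, 1 oxygen; one six-membered non-aromatic ring of carbon only), on a double-bonded ring carbon. The measured steps that bear on this position are a 1.8-fold lower number from compound 1 to compound 3 (0.25 log units; within the scatter) and a 1.6-fold higher number from compound 2 to compound 3 (0.21 log units; within the scatter), both within the scatter, while a 2.8-fold lower number from compound 1 to compound 2 (0.45 log units; beyond the scatter) is modest. Exchanges at this double-bonded ring carbon have so far moved this assay little. For compound 4 the expected step is a 1.2-fold higher number from compound 3 to compound 4 (0.06 log units; within the scatter), none beyond the scatter. Compound 4 is therefore estimated at 15 nM, with a range from 6 nM to 40 nM.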

Compound 4, half-maximal inhibitory concentration: 9.6 nM
Compound 4: middle estimate off by 1.6-fold (0.19 log units), on the high side; low and high end bracket the measured number.
By their numbers in this assay, from the lowest: compounds 2, 4, 3 and 1 (each within the scatter of the next, the first and the last beyond it).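

The exchange of 4-hydroxycyclohex-1-en-1-yl for the oxygen-containing ring gives a 1.4-fold lower number from compound 3 to compound 4 (0.13 log units; within the scatter) in this assay, so this position tolerates a group with 0 hydrogen-bond donors. Against the aromatic pyridin-4-yl the same ring gives a 1.2-fold higher number from compound 2 to compound 4 (0.07 log units; within the scatter) and a non-aromatic ring therefore holds level with it here, while against 4-(hydroxymethyl)phenyl it gives a 2.4-fold lower number from compound 1 to compound 4 (0.38 log units; beyond the scatter) as a modest step. No available evidence accounts for these steps.

Open, on these data alone, is whether an amine or a carboxylic acid on this double-bonded ring carbon would stay in this range. As far as these compounds go, a longer chain in place of the ring is equally open.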